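The compounds below may be only part of what the source reports. "The series", "measured", "known", "first", "only" and "open" are said of these compounds alone.

Measured compounds:
compound 1, `O=[N+]([O-])c1ccc(-c2nc3ccc(Br)cc3[nH]2)cc1`: 10000 nM
compound 2, `Cc1ccc2nc(-c3ccc([N+](=O)[O-])cc3)[nH]c2c1`: 22000 nM

Both compounds were tested in an assay on cells for inhibition of matrix metalloproteinase-9 (Homo sapiens), read by fluorescence, with stated times of 15 min and 4 h; a higher number here means a weaker inhibitor, a lower number a stronger inhibitor. Compound 1 gives 10000 nM, and compound 2 gives 22000 nM, the higher of the two numbers, so compound 2 is the weaker inhibitor of the pair. Going by the values given here, the one measured step, a 2.2-fold higher number from compound 1 to compound 2 (0.34 log units; beyond the scatter), alters the group on the same aromatic carbon that is altered next. Compound 3, `O=[N+]([O-])c1ccc(-c2nc3ccccc3[nH]2)cc1`, differs from compound 2 by hydrogen in place of methyl on an aromatic carbon. This step has no direct measured counterpart: the only step shown swaps one substituent for another at this carbon, and it was modest, so removing the methyl altogether is expected to shift the number only by a 1.1-fold lower number from compound 2 to compound 3 (0.04 log units; within the scatter), within or barely beyond the scatter, with no firm direction. In this assay compound 3 is therefore estimated at 20000 nM, with a range from 8000 nM to 50000 nM.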

Compound 3, half-maximal inhibitory concentration: 56500 nM
For compound 3 the middle estimate is 2.8-fold (0.45 log units) below the measured one; the whole stated range lies below it.
By their numbers in this assay, from the lowest: compound 1; then compound 2; then compound 3.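

In this assay the unsubstituted carbon turns out to be the poorest of the three cases: hydrogen in place of methyl gives a 2.6-fold higher number from compound 2 to compound 3 (0.41 log units; beyond the scatter), and hydrogen in place of bromo gives a 5.7-fold higher number from compound 1 to compound 3 (0.75 log units; beyond the scatter). The earlier pair showed only that bromo and methyl differ from each other, whereas compound 3 now shows that each of them gives a stronger inhibitor than hydrogen does at this carbon, with bromo the better of the two. Nothing measured here explains why the number moves this way.

On these data alone, whether an amine, a carboxylic acid or a longer chain on this carbon would bring the number below that of compound 1 remains open. So does whether the same order of bromo, methyl and hydrogen would hold on a core changed elsewhere.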